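Moving the substituent on the benzamide ring

The compounds below may be only part of what the source reports. "The series", "measured", "known", "first", "only" and "open" are said of these compounds alone.

Compound 1, `CCN1CCN(c2cc(C)c3cc(NC(=O)c4ccccc4F)ccc3n2)CC1`, is the weakest of three closely related benzamides in a functional assay on SK-BR-3 cells (Homo sapiens) for antiproliferative activity, read by MTT assay, with a stated time of 72 h (a lower number here means a stronger inhibitor, a higher number a weaker inhibitor), where compound 1 gives 38100 nM. Its companions keep the shared core and change only the ring attached to the carbonyl. Compound 2, `CCN1CCN(c2cc(C)c3cc(NC(=O)c4ccc(F)cc4)ccc3n2)CC1`, gives 19800 nM, and compound 3, `CCN1CCN(c2cc(C)c3cc(NC(=O)c4ccc(Br)cc4)ccc3n2)CC1`, gives 6310 nM. The step of a 1.9-fold lower number from compound 1 to compound 2 (0.28 log units; within the scatter) stays within the scatter, whereas a 6.0-fold lower number from compound 1 to compound 3 (0.78 log units; beyond the scatter) and a 3.1-fold lower number from compound 2 to compound 3 (0.50 log units; beyond the scatter) are modest but real gains.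

Compound 4, `CCN1CCN(c2cc(C)c3cc(NC(=O)c4cccc(C)c4)ccc3n2)CC1`, has not yet been measured. It differs from compound 1 in one place: 3-methylphenyl in place of 2-fluorophenyl on a carbonyl carbon. The measured steps that bear on this change are the two that also start from compound 1, since both likewise replace the 2-fluorophenyl with a differently substituted phenyl. For the measured compounds named here, one of them stayed within the scatter and the other gave a modest gain, so a small to modest gain is the expectation here, though no measured compound carries a methyl on this ring, and a flat result would not be surprising.

For compound 4 the expected step is a 2.4-fold lower number from compound 1 to compound 4 (0.38 log units; beyond the scatter), giving an estimate of 16000 nM with a range from 5000 nM to 50000 nM.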

Compound 4, half-maximal inhibitory concentration: 13700 nM
Compound 4: the middle estimate sits 1.2-fold (0.07 log units) above what was measured; measured number inside the range.
By their numbers in this assay, from the lowest: compound 3; then compounds 4, 2 and 1 (each within the scatter of the next, the first and the last beyond it).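

The 3-methylphenyl ring carries a carbon-only substituent rather than a halogen, yet it still gives a real gain over the 2-fluorophenyl ring in this assay, with a 2.8-fold lower number from compound 1 to compound 4 (0.44 log units; beyond the scatter), so among these four compounds a halogen on this ring is not required to move beyond the scatter from compound 1. The methyl compound nonetheless falls short of the 4-bromophenyl compound, with a 2.2-fold higher number from compound 3 to compound 4 (0.34 log units; beyond the scatter), while it cannot be separated from the 4-fluorophenyl compound, with a 1.4-fold lower number from compound 2 to compound 4 (0.16 log units; within the scatter), which places it in an intermediate group rather than at either end of the series. Nothing shown here gives a measured reason for these differences.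

Each of these swaps changes the substituent and its place on the ring together, so a 4-methylphenyl or 3-bromophenyl ring would be needed to tell the effect of the group from that of its place. Going by these compounds, how a ring bearing an amine or a carboxylic acid would behave in this assay also remains open.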